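Acetylation of the aromatic amine on two cores

The source may report more compounds than this note shows. Statements on the series, on what has been measured and on what is new or still open speak of the compounds shown alone.

Measured so far:
compound 1 `Nc1ccc(-c2cn([C@@H]3CN[C@H](C(=O)Nc4ccc(Cl)c(C(F)(F)F)c4)C3)nn2)cn1`: 10400 nM in a functional assay on K562 cells (Homo sapiens) for inhibition, read by MTT assay, with a stated time of 48 h; a higher number here means a weaker inhibitor, a lower number a stronger inhibitor
compound 2 `CC(=O)Nc1ccc(-c2cn([C@@H]3CN[C@H](C(=O)Nc4ccc(Cl)c(C(F)(F)F)c4)C3)nn2)cn1`: 8980 nM in this assay
compound 3 `Nc1nc2ccc(-c3cn([C@@H]4CN[C@H](C(=O)Nc5ccc(Cl)cc5Cl)C4)nn3)nc2s1`: 24500 nM in this assay

Among the measured compounds shown here, the only counted step among the measured compounds is a 1.2-fold lower number from compound 1 to compound 2 (0.06 log units; within the scatter), brought about by acetyl in place of hydrogen on a nitrogen on an aromatic ring. Compound 3 has a different core from compound 1; the difference between the two cores is not broken down here, and compound 3 stands highest of the three numbers, beyond the scatter from both others.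

Compound 4 `CC(=O)Nc1nc2ccc(-c3cn([C@@H]4CN[C@H](C(=O)Nc5ccc(Cl)cc5Cl)C4)nn3)nc2s1` is not yet measured. It differs from compound 3 by acetyl in place of hydrogen on a nitrogen on an aromatic ring, the same change as that from compound 1 to compound 2, at a place described in the same words. The step is expected to be small, estimated as a 1.2-fold lower number from compound 3 to compound 4 (0.07 log units; within the scatter), because a 1.2-fold lower number from compound 1 to compound 2 (0.06 log units; within the scatter) was within the scatter. Compound 4 is therefore expected near 21000 nM in this assay, between 9000 nM and 48000 nM.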

Compound 4, half-maximal inhibitory concentration: 9670 nM
Beside the measured number, compound 4's estimate is 2.2-fold (0.34 log units) above it; the measured number falls inside the stated range.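

In this assay, acetyl in place of hydrogen on a nitrogen on an aromatic ring gives a 2.5-fold lower number from compound 3 to compound 4 (0.40 log units; beyond the scatter), whereas on the core of compound 1 the same change stayed within the scatter. Set side by side, the two steps do not differ beyond what repeated measurements allow: the same change on two cores in this assay, a 1.2-fold lower number (0.06 log units; within the scatter) from compound 1 to compound 2 and a 2.5-fold lower number (0.40 log units; beyond the scatter) from compound 3 to compound 4, 2.2-fold (0.34 log units) apart, within the scatter of two such steps. The change therefore shows no demonstrated dependence on the core, but two cores cannot establish that the steps are equal, and nothing here explains the larger step seen with compound 4.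

Open, from the compounds shown here alone, is whether a longer acyl chain, such as propionyl, or a simple methyl on that nitrogen would behave in the same way. Going by these compounds, compound 1 and compound 3 differ in more than one place, so what each part contributes also stays open.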